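Urea-to-amide swap in a pyrazole series, growth inhibition

This account rests on a few compounds, and the source may have more. Where it says the series, first, only, none or still open, it means among the compounds named here.

Measured compounds:
Compound 1 `O=C(Nc1cccc(-n2cc(-c3ccncc3)c(-c3cc(O)cc(Cl)c3)n2)c1)Nc1ccc(Cl)c(C(F)(F)F)c1` gives 105% in a functional assay on SR cells (Homo sapiens) for inhibition, read by sulforhodamine B assay, with a stated time of 48 h, tested at 0.01 uM; a higher number here means a weaker effect of the compound at the concentration tested, a lower number a stronger effect.
Compound 2 `COc1cc(Cl)cc(-c2nn(-c3cccc(NC(=O)Nc4ccc(Cl)c(C(F)(F)F)c4)c3)cc2-c2ccncc2)c1` gives 95% in this assay.
Compound 3 `COc1cc(Cl)cc(-c2nn(-c3cccc(NC(=O)Nc4cc(C(F)(F)F)cc(C(F)(F)F)c4)c3)cc2-c2ccncc2)c1` gives 101% in this assay.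

Compound 2 sits at a level that compound 1 and compound 3 both match within the scatter; none of the three shows an effect at this concentration. Compound 4 `COc1cc(Cl)cc(-c2nn(-c3cccc(NC(=O)c4cccc(C(F)(F)F)c4)c3)cc2-c2ccncc2)c1` differs from compound 2 in that (3-(trifluoromethyl)phenyl in place of (4-chloro-3-(trifluoromethyl)phenyl)amino on a carbonyl carbon), at the carbonyl carbon whose other neighbour is the amide-type nitrogen. Among the compounds with values here, no measured step touches this position; the only step, a number 10 percentage points lower from compound 1 to compound 2 (within the scatter), concerns the oxygen on the aromatic ring and lies within the scatter. Compound 2 and compound 3 show that two different aryl groups on the urea give matching numbers. Compound 4 is therefore expected to stay near compound 2, with a number 3 percentage points higher from compound 2 to compound 4 (within the scatter) lying within the scatter, at an estimated 98% (range 86% to 110%).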

Compound 4, a percentage reported as activity, at one concentration (the size of the read-out at that concentration, not a potency): 57%
The estimate for compound 4 lay 41 percentage points above the measured number; the whole stated range lies above it.
By their numbers in this assay, from the lowest: compound 4; then compounds 2, 3 and 1 (each within the scatter of the next).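

Within the data shown here, putting 3-(trifluoromethyl)phenyl in place of (4-chloro-3-(trifluoromethyl)phenyl)amino on the carbonyl carbon gives the only step beyond the scatter in this assay (a number 38 percentage points lower from compound 2 to compound 4 (beyond the scatter)), so this position responds where the earlier changes did not. The change removes the amino nitrogen and the chlorine together, so the step cannot be assigned to either one alone. Nothing available accounts for the step.

Still open, on these data alone, is whether 4-chloro-3-(trifluoromethyl)phenyl on the carbonyl carbon would give a similar number, and how a benzylamine or a morpholine would behave at this position.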